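Methyl Gives Way to a Larger Group on Nitrogen

A few compounds are considered here, and "the series" means these few. Any claim that something is new, unique, unknown or untested is made for them only; others in the source may bear on it.

Compound 1 `COc1cc(-c2ccnc3cc(-c4cn(CO)c5ccccc45)nn23)cc(OC)c1OC`: 128 nM
Compound 2 `COc1cc(-c2ccnc3cc(-c4c[nH]c5ccccc45)nn23)cc(OC)c1OC`: 35 nM
Compound 3 `COc1cc(-c2ccnc3cc(-c4cn(C)c5ccccc45)nn23)cc(OC)c1OC`: 762 nM

In a functional assay on HCT-116 cells (Homo sapiens) for inhibition, read by CCK-8 assay, with a stated time of 48 h (on this read-out higher numbers stand for weaker inhibition and lower numbers for stronger inhibition), compound 3 gives the highest number of the three (762 nM), which makes it the weakest inhibitor so far. Compound 4 `COc1cc(-c2ccnc3cc(-c4cn(C(=O)OC(C)(C)C)c5ccccc45)nn23)cc(OC)c1OC` carries tert-butoxycarbonyl in place of methyl on an aromatic nitrogen. Three measured steps change that same nitrogen. The large one (a 22-fold higher number from compound 2 to compound 3 (1.34 log units; beyond the scatter)) puts methyl in place of hydrogen, while two modest ones (a 3.7-fold lower number from compound 1 to compound 2 (0.56 log units; beyond the scatter); a 6.0-fold higher number from compound 1 to compound 3 (0.77 log units; beyond the scatter)) involve hydroxymethyl. Among the measured compounds shown here, compound 1 and compound 3, both substituted there, give higher numbers than compound 2, but no measured step starts from methyl and ends in a group this large. What is expected for compound 4 in this assay is a small step, perhaps none beyond the scatter, in an uncertain direction (a 1.2-fold higher number from compound 3 to compound 4 (0.07 log units; within the scatter)). Compound 4 is estimated at 900 nM (from 200 nM to 4000 nM).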

Compound 4, half-maximal inhibitory concentration: 5720 nM
Estimate against measurement, compound 4: 6.4-fold (0.80 log units) below; the measured number lies above the stated range.
By their numbers in this assay, from the lowest: compound 2; then compound 1; then compound 3; then compound 4.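

In this assay, tert-butoxycarbonyl on the aromatic nitrogen gives a clearly weaker result than methyl, a 7.5-fold higher number from compound 3 to compound 4 (0.88 log units; beyond the scatter). The gaps to the other two compounds are larger still, a 45-fold higher number from compound 1 to compound 4 (1.65 log units; beyond the scatter) and a 160-fold higher number from compound 2 to compound 4 (2.21 log units; beyond the scatter), so every substituent shown on this nitrogen gives a higher number than hydrogen, though hydroxymethyl, the larger group, gives a lower number than methyl, which goes against a simple order by size. No measured evidence accounts for this rise. On these data alone, whether it follows the carbonyl or the tert-butyl part stays open; an acetyl group or a butyl chain on this nitrogen could separate the two.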